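Notes on the step from compound 3 to compound 4

The source may hold more compounds than are shown below. What is called first, only, known or untested is meant among the compounds shown, and "the series" means these compounds.

Measured in an ADME assay on HepG2 cells (Homo sapiens) for cytotoxicity, read by MTT assay, with a stated time of 24 h; on this read-out higher numbers stand for lower toxicity in this test and lower numbers for higher toxicity in this test:
- compound 1 `CC1Cn2c(nc([N+](=O)[O-])c2Br)O1` gives 20100 nM
- compound 2 `CC1Cn2c(nc([N+](=O)[O-])c2C#Cc2ccc(CO)cc2)O1` gives 9000 nM
- compound 3 `CC1Cn2c(nc([N+](=O)[O-])c2C#Cc2cccc(N)c2)O1` gives 8300 nM

Compound 3 lies within the scatter of compound 2 and beyond the scatter under compound 1. Compound 4 `CC1Cn2c(nc([N+](=O)[O-])c2C#Cc2ccccc2)O1` differs from compound 3 by hydrogen in place of amino on an aromatic carbon, with hydrogen in place of amino on an aromatic carbon, so 3-aminophenyl becomes phenyl. Among the measured compounds shown here, no measured pair isolates this change. Compound 2 (9000 nM) and compound 3 (8300 nM) carry different groups yet fall within the scatter of each other, so no step beyond the scatter is expected in this assay. The expected change is a 1.1-fold higher number from compound 3 to compound 4 (0.04 log units; within the scatter), a step within the scatter. The estimate for compound 4 is 9000 nM (expected range 4500 nM to 18000 nM).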

Compound 4, half-maximal cytotoxic concentration: 5400 nM
Estimate against measurement, compound 4: 1.7-fold (0.22 log units) above; low and high end bracket the measured number.
By their numbers in this assay, from the lowest: compounds 4, 3 and 2 (each within the scatter of the next); then compound 1.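

Hydrogen in place of amino on an aromatic carbon gives a 1.5-fold lower number from compound 3 to compound 4 (0.19 log units; within the scatter), and hydrogen in place of hydroxymethyl gives a 1.7-fold lower number from compound 2 to compound 4 (0.22 log units; within the scatter), both read in this assay. With the unsubstituted phenyl as a reference, neither amino nor hydroxymethyl on the ring separates from it beyond the scatter in this test. No supporting data bear on the origin of these small steps.

From the compounds shown here alone, whether a carboxylic acid or a dimethylamino group on the phenyl ring would give a step beyond the scatter remains open.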